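Swapping an Amine for a Methoxymethyl Group

The source may report more compounds than this note shows. Statements on the series, on what has been measured and on what is new or still open speak of the compounds shown alone.

Of the compounds shown here, two have been measured in an assay on isolated protein for inhibition of Retinaldehyde dehydrogenase 3 (Homo sapiens), tested at 5 uM; a lower number here means less inhibition, a higher number more inhibition at the concentration tested (going by the name of the read-out). Compound 1 `COc1ccc(C(C)Sc2nc3c(cnn3C)c(=O)n2-c2ccccc2)cc1` gives 39%, and compound 2 `CC(Sc1nc2c(cnn2C)c(=O)n1-c1ccc(CN)cc1)c1ccccc1` gives 56%, the higher of the two numbers and beyond the scatter from compound 1. Compound 3 `COCCc1ccc(-n2c(SC(C)c3ccccc3)nc3c(cnn3C)c2=O)cc1` has not yet been measured; it differs from compound 2 by methoxymethyl in place of amino on a saturated chain carbon bound to an aromatic carbon. Among the measured compounds shown here, no measured pair shows this change, so its size is unknown. The change removes a hydrogen-bond donor, and a modest fall in this assay is expected. Compound 3 is estimated at 40%, between 20% and 60%. The expected step is a number 16 percentage points lower from compound 2 to compound 3 (beyond the scatter).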

Compound 3, a percentage reported as inhibition, at one concentration (the size of the read-out at that concentration, not a potency): 34%
Beside the measured number, compound 3's estimate is 6 percentage points above it; the range from low to high includes it.
By their numbers in this assay, from the lowest: compounds 3 and 1 (each within the scatter of the next); then compound 2.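

In this assay, methoxymethyl in place of amino on a saturated chain carbon bound to an aromatic carbon gives a number 22 percentage points lower from compound 2 to compound 3 (beyond the scatter), so inhibition at this position depends on the group at the end of the chain. This single change removes the hydrogen-bond donor and also adds heavy atoms, and one pair cannot separate those two differences. Nothing measured here gives a reason for the step. Going by these compounds, it remains open whether a hydroxyl or a dimethylamino group on the same chain carbon would read closer to compound 2 or to compound 3.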